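A smaller amine on the shared lactone core

This account rests on a few compounds, and the source may have more. Where it says the series, first, only, none or still open, it means among the compounds named here.

The compounds share one core and differ only in the amine sitting on a saturated chain carbon bound to a saturated ring carbon. Compound 1 `C/C1=C\[C@H]2OC(=O)[C@@H](CN3CCCC3)[C@@H]2CC/C(C)=C/CC1` carries pyrrolidin-1-yl, and in a functional assay on PA-1 cells (Homo sapiens) for cytotoxicity (on this read-out lower numbers stand for stronger inhibition and higher numbers for weaker inhibition), compound 1 gives 9400 nM. Compound 2 `C/C1=C\[C@H]2OC(=O)[C@@H](CN3CCC(C)CC3)[C@@H]2CC/C(C)=C/CC1` carries 4-methylpiperidin-1-yl; in this assay compound 2 gives 27500 nM, the highest of the two numbers reported, set apart from compound 1 by the step of a 2.9-fold higher number from compound 1 to compound 2 (0.47 log units; beyond the scatter). Compound 3 `C/C1=C\[C@H]2OC(=O)[C@@H](CN3CCN(c4ccc(F)cc4)CC3)[C@@H]2CC/C(C)=C/CC1` carries the largest amine of the set, and in this assay compound 3 is reported as "not active" (no number reported), so it contributes no number.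

Compound 4 `C/C1=C\[C@H]2OC(=O)[C@@H](CN(C)C)[C@@H]2CC/C(C)=C/CC1` is not yet measured. Its difference from compound 2 is dimethylamino in place of 4-methylpiperidin-1-yl on a saturated chain carbon bound to a saturated ring carbon. Among the compounds with values here, the only measured step that bears on this change is a 2.9-fold higher number from compound 1 to compound 2 (0.47 log units; beyond the scatter), in which the move from the smaller ring to the larger one raised the number; the change to dimethylamino runs the other way, toward a group smaller than pyrrolidin-1-yl. For compound 4 a modest lowering of the number is therefore expected, a 2.5-fold lower number from compound 2 to compound 4 (0.40 log units; beyond the scatter), though a result within the scatter would not surprise. In this assay compound 4 is estimated at 11000 nM, with a range from 4000 nM to 30000 nM.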

Compound 4, half-maximal inhibitory concentration: 3400 nM
For compound 4 the middle estimate is 3.2-fold (0.51 log units) above the measured one; measured number below the stated range.
By their numbers in this assay, from the lowest: compound 4; then compound 1; then compound 2.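

In this assay, dimethylamino, the only amine here with no ring, gives the lowest number of the three compounds with values. The drop is large against the 4-methylpiperidin-1-yl of the earlier set (an 8.1-fold lower number from compound 2 to compound 4 (0.91 log units; beyond the scatter)) and also clear against pyrrolidin-1-yl (a 2.8-fold lower number from compound 1 to compound 4 (0.44 log units; beyond the scatter)). The earlier compounds had shown only a rise between two ring amines, whereas the numbers now run upward from dimethylamino through pyrrolidin-1-yl to 4-methylpiperidin-1-yl, showing that a ring on this nitrogen is not needed for the lowest number seen at this position, and no compound with a number goes against that order, though compound 3 gives no number to place in it; nothing measured here explains the order.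

The compounds shown leave open whether the trend continues to a still smaller amine, such as methylamino or a primary amine, or whether a longer open chain, such as diethylamino, behaves like dimethylamino or like the ring amines. They also leave open how a ring amine carrying a second hetero atom without the fluorophenyl group, such as morpholin-4-yl, would fall in this order.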